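A few compounds are considered here, and "the series" means these few. Any claim that something is new, unique, unknown or untested is made for them only; others in the source may bear on it.

Compound 1 `Cn1ccc2c(Oc3ccc(NC(=O)c4cn(-c5ccc(F)cc5)c5ccccc5c4=O)cc3F)ccnc21`, compound 2 `Cn1ccc2c(Oc3ccc(NC(=O)c4cn(-c5ccc(Br)cc5F)c5ccccc5c4=O)cc3F)ccnc21`, compound 3 `O=C(Nc1ccc(Oc2ccnc3[nH]ccc23)c(F)c1)c1cn(-c2ccc(F)cc2)c2ccccc2c1=O` and compound 4 `O=C(Nc1ccc(Oc2ccnc3[nH]ccc23)c(F)c1)c1cn(-c2ccc(Br)cc2F)c2ccccc2c1=O` share one core, and compound 1 and compound 2 differ from compound 3 and compound 4 in a further place on that core. In a functional assay on MCF7 cells (Homo sapiens) for inhibition, read by MTT assay, with a stated time of 72 h (a lower number here means a stronger inhibitor, a higher number a weaker inhibitor), compound 1 gives "not determined" (no result reported), so no number is available for it. In this assay compound 2 gives 420 nM. In this assay, for the measured compounds named here, compound 3 gives 520 nM, the higher of the two numbers measured so far, yet its gap to compound 2 lies within the scatter of repeated measurements, so the two cannot be separated.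

Compound 4 is compound 3 with 4-bromo-2-fluorophenyl in place of 4-fluorophenyl on an aromatic nitrogen. Going by the values given here, no pair of measured compounds isolates this change, and the only hint comes from compound 2, which carries the same 4-bromo-2-fluorophenyl group and sits within the scatter of compound 3. The step from compound 3 to compound 4 is therefore expected to be small, no larger than the scatter, as a 1.2-fold lower number from compound 3 to compound 4 (0.06 log units; within the scatter) expresses. Compound 4 is estimated at 450 nM, with a range from 150 nM to 1400 nM.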

Compound 4, half-maximal inhibitory concentration: 1390 nM
The estimate for compound 4 lay 3.1-fold (0.49 log units) below the measured number; low and high end bracket the measured number.
By their numbers in this assay, from the lowest: compounds 2 and 3 (each within the scatter of the next); then compound 4.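

Replacing 4-fluorophenyl with 4-bromo-2-fluorophenyl on the aromatic nitrogen gives a 2.7-fold higher number from compound 3 to compound 4 (0.43 log units; beyond the scatter) in this assay, so this position does respond to the group it carries, and this swap weakens inhibition. The other aromatic nitrogen also counts when 4-bromo-2-fluorophenyl is in place, since hydrogen in place of methyl there gives a 3.3-fold higher number from compound 2 to compound 4 (0.52 log units; beyond the scatter), again towards weaker inhibition. Nothing available here explains either step.

With 4-fluorophenyl in place, the same swap of methyl for hydrogen cannot be read: compound 1 offers no number to compare. Also open, as far as these compounds go, is whether the weaker inhibition follows the bromine or the added fluorine, and how a plain phenyl, a 4-chlorophenyl or an ethyl chain would behave on this nitrogen.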